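The source may hold more compounds than are shown below. What is called first, only, known or untested is meant among the compounds shown, and "the series" means these compounds.

Measured in a functional assay on the whole organism with Canis familiaris (Canis lupus familiaris) as the target; on this read-out lower numbers stand for an effect already at smaller amounts and higher numbers for an effect only at larger amounts of compound:
- Compound 1 `C/C=C(C)\C=C\[C@](C)(O)C/C=C/[C@H]1[C@H](O)CC(=O)[C@@H]1CC/C=C\CCC(=O)OC`: 0.000016 mg/kg
- Compound 2 `C/C=C(C)/C=C/[C@](C)(O)C/C=C/[C@H]1[C@H](O)CC(=O)[C@@H]1CC/C=C\CCC(=O)OC`: 0.000003 mg/kg

Of these two, compound 1 has the higher number, so it needs the larger dose for the same effect. Its nearest and only neighbour is compound 2, and the gap is a 5.3-fold lower number from compound 1 to compound 2 (0.73 log units; beyond the scatter). This gap lies beyond the usual scatter and comes with the fact that compounds 1 and 2 differ only in the configuration as drawn.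

Compound 3 `C=C(C)/C=C/[C@](C)(O)C/C=C/[C@H]1[C@H](O)CC(=O)[C@@H]1CC/C=C\CCC(=O)OC` differs from compound 1 in its end group: 1-methylethenyl in place of 1-methylprop-1-en-1-yl on a double-bonded chain carbon bound to a double-bonded chain carbon. In words, 1-methylethenyl stands in place of 1-methylprop-1-en-1-yl on a double-bonded chain carbon bound to a double-bonded chain carbon. The new end group cannot be drawn as Z or E, so compound 3 matches neither compound 1 nor compound 2 in that respect.

Going by the values given here, no measured step covers the loss of this end carbon. The step to compound 2, a 5.3-fold lower number from compound 1 to compound 2 (0.73 log units; beyond the scatter), therefore serves only as a rough guide to size, and it gives no firm direction. In this assay, the expected change is small, a 1.8-fold lower number from compound 1 to compound 3 (0.25 log units; within the scatter), with no clear move beyond the scatter. For compound 3, the estimated value is 0.000009 mg/kg, with an expected range of 0.000002 mg/kg to 0.00004 mg/kg.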

Compound 3, dose for half-maximal effect: 0.00002 mg/kg
For compound 3 the middle estimate is 2.2-fold (0.35 log units) below the measured one; low and high end bracket the measured number.
By their numbers in this assay, from the lowest: compound 2; then compounds 1 and 3 (each within the scatter of the next).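

In this assay, putting 1-methylethenyl in place of 1-methylprop-1-en-1-yl gives a 1.3-fold higher number from compound 1 to compound 3 (0.10 log units; within the scatter), so this change at this position cannot be told apart from no change when compound 1 is the starting point. The same exchange starting from compound 2 gives a 6.7-fold higher number from compound 2 to compound 3 (0.82 log units; beyond the scatter), which shows that the size of the step depends on which form of the longer end group it starts from, and not only on the carbon that is lost. Compound 3 therefore sits with compound 1, and compound 2 alone stands apart from both, with its separation from compound 1 resting on a single known difference: the fact that compounds 1 and 2 differ only in the configuration as drawn.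

The compounds shown leave open how much else this end of the molecule accepts on a double-bonded chain carbon bound to a double-bonded chain carbon, for example a longer chain, an amine or a carboxylic acid in place of 1-methylethenyl. They also leave open whether the low number of compound 2 is tied to 1-methylprop-1-en-1-yl or would return with another end group that can be drawn E.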